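A few compounds are considered here, and "the series" means these few. Any claim that something is new, unique, unknown or untested is made for them only; others in the source may bear on it.

Of the compounds shown here, three built on one shared core have been measured in an assay on Sf9 cells for inhibition of serine/threonine-protein kinase 4 (Homo sapiens), read by luminescence and ADP-Glo, with a stated time of 1 h, in the presence of a further agent that is not named here; a higher number here means a weaker inhibitor, a lower number a stronger inhibitor. Compound 1 `CN1CC(=O)N(C)c2cnc(Nc3ccc(S(N)(=O)=O)cc3)nc21` gives 495 nM, and compound 2 `CCC1C(=O)N(C)c2cnc(Nc3ccc(S(N)(=O)=O)cc3)nc2N1C`, which carries an ethyl in place of hydrogen on a saturated ring carbon, gives 479 nM; the step of a 1.0-fold lower number from compound 1 to compound 2 (0.01 log units; within the scatter) lies within the scatter. Compound 3 `CN1C(=O)C(c2ccccc2F)N(C)c2nc(Nc3ccc(S(N)(=O)=O)cc3)ncc21`, with a 2-fluorophenyl on that saturated ring carbon, gives 75 nM, the lowest of the three numbers, and the steps of a 6.6-fold lower number from compound 1 to compound 3 (0.82 log units; beyond the scatter) and a 6.4-fold lower number from compound 2 to compound 3 (0.81 log units; beyond the scatter) both lie beyond the scatter. Compound 4 `CN1C(=O)C(c2ccccc2Br)N(C)c2nc(Nc3ccc(S(N)(=O)=O)cc3)ncc21` is not yet measured; it differs from compound 3 by bromo in place of fluoro on an aromatic carbon. Among the measured compounds shown here, no measured step touches the fluoro of compound 3: the two steps that lie beyond the scatter changed the group on the saturated ring carbon itself, and the one step that kept a small group there stayed within the scatter. The data give nothing to scale an exchange of one halogen for another, so the expected step is a 1.1-fold lower number from compound 3 to compound 4 (0.03 log units; within the scatter), within the scatter. Compound 4 is estimated at 70 nM, between 30 nM and 170 nM.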

Compound 4, half-maximal inhibitory concentration: 57 nM
Beside the measured number, compound 4's estimate is 1.2-fold (0.09 log units) above it, and the stated range covers the measured number.
By their numbers in this assay, from the lowest: compounds 4 and 3 (each within the scatter of the next); then compounds 2 and 1 (each within the scatter of the next).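

In this assay, the step of a 1.3-fold lower number from compound 3 to compound 4 (0.12 log units; within the scatter) is the only one shown that alters the aromatic ring while keeping the group on the saturated ring carbon otherwise the same, and it shows that bromo and fluoro cannot be told apart at this aromatic carbon. The separation from the smaller groups holds with the heavier halogen as well: the steps of an 8.4-fold lower number from compound 2 to compound 4 (0.92 log units; beyond the scatter) and an 8.7-fold lower number from compound 1 to compound 4 (0.94 log units; beyond the scatter) both lie beyond the scatter, so it is not confined to the 2-fluorophenyl of compound 3. No evidence is available to explain why these two halogens read alike.

The compounds shown leave open how a plain phenyl, or a methoxy or an amine on that aromatic carbon, would read. They also leave open how a longer chain or a cyclohexyl on the saturated ring carbon would compare with 2-bromophenyl.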